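This account rests on a few compounds, and the source may have more. Where it says the series, first, only, none or still open, it means among the compounds named here.

Measured so far:
compound 1 `CCCCCCCCCCCCn1nnc(C(C(=O)Nc2c(C)nn(C)c2C)c2ccccc2)n1`: 13 nM
compound 2 `CCCCCCCCCCCCn1nnc(C(C(=O)Nc2ccc3c(C)cc(C)nc3n2)c2ccccc2)n1`: 1540 nM

For the measured compounds named here, compound 2 carries the highest number of the two in an assay on liver for inhibition of sterol O-acyltransferase 1 (Rattus norvegicus), using microsomes (on this read-out lower numbers stand for stronger inhibition and higher numbers for weaker inhibition), that is, the weaker inhibition; the one step toward it is a 120-fold higher number from compound 1 to compound 2 (2.07 log units; beyond the scatter). Compound 3 `CCCCCCCCCCCCn1nnc(C(C(=O)NC2CC2)c2ccccc2)n1` is compound 2 with a group of 3 heavy atoms (3 carbon; one three-membered non-aromatic ring of carbon only) in place of a group of 12 heavy atoms (10 carbon, 2 nitrogen; 2 six-membered aromatic rings with 1 hetero atom each), on an amide-type nitrogen. Going by the values given here, only that single step touches this place, and it showed a large rise when the group on the amide nitrogen grew; compound 3 shrinks it instead, yet to a non-aromatic ring no measured compound carries, so the direction can be guessed, the size only loosely. In this assay the expected step is a fall, smaller than the one already seen: a 5.1-fold lower number from compound 2 to compound 3 (0.71 log units; beyond the scatter). Compound 3 is estimated at 300 nM, within 40 nM to 3000 nM.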

Compound 3, half-maximal inhibitory concentration: 244 nM
For compound 3 the middle estimate is 1.2-fold (0.09 log units) above the measured one; measured number inside the range.
By their numbers in this assay, from the lowest: compound 1; then compound 3; then compound 2.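

With cyclopropyl on the amide-type nitrogen, this assay shows a 6.3-fold lower number from compound 2 to compound 3 (0.80 log units; beyond the scatter) but also a 19-fold higher number from compound 1 to compound 3 (1.27 log units; beyond the scatter), so group size alone does not set the order at this position: the smallest group gives neither the lowest nor the highest number, and the lowest belongs to the mid-sized 1,3,5-trimethyl-1H-pyrazol-4-yl of compound 1. Nothing available explains this order. Still open, going by these compounds, is where an open butyl chain, or a 1H-pyrazol-4-yl without its methyl groups, would fall on the amide-type nitrogen relative to compound 1 and compound 3.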